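Methoxy to tert-butyl on the shared core

The compounds below may be only part of what the source reports. "The series", "measured", "known", "first", "only" and "open" are said of these compounds alone.

Measured so far:
compound 1 `CC(C)n1ncc2c(C(=O)NCc3cn(Cc4ccc(C(F)(F)F)cc4)nn3)cccc21` – > 40000 nM
compound 2 `COc1ccc(Cn2cc(CNC(=O)c3cccc4c3cnn4C(C)C)nn2)cc1` – > 40000 nM

In a functional assay on MGC-803 cells (Homo sapiens) for inhibition, read by MTT assay, with a stated time of 72 h (a higher number here means a weaker inhibitor, a lower number a stronger inhibitor), compound 1 gives > 40000 nM, which is a limit of the assay and not a number. Compound 2 gives > 40000 nM, likewise a limit. Within the data shown here, the one step between them, a step that the two limits leave unreadable from compound 1 to compound 2, is accordingly of unreadable size. Compound 2 therefore stands at the limit with no number to place it against; both measured values sit at the limit of > 40000 nM in this assay, at which 2 of the 2 values shown sit.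

Compound 3 `CC(C)n1ncc2c(C(=O)NCc3cn(Cc4ccc(C(C)(C)C)cc4)nn3)cccc21` differs from compound 2 by tert-butyl in place of methoxy on an aromatic carbon. Among the measured compounds shown here, the single measured step concerns a change at the same place on the same ring, but as a step that the two limits leave unreadable from compound 1 to compound 2 cannot be read, neither size nor direction can be taken from it. The measured pair shows no change that brought a compound into the readable range, so for compound 3 in this assay the expectation is no step beyond the scatter and, most likely, another limit. Compound 3 is estimated at 40000 nM, with a range from 15000 nM to 100000 nM. The estimated step is a number no higher from compound 2 to compound 3 (the limit leaves the size open), essentially none.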

Compound 3, half-maximal inhibitory concentration: > 40000 nM
Compound 3 gave a limit, no number (the forecaster's own chance of this, stated with the estimate: 80%); the middle value sits exactly at the limit.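

In this assay compound 3 gives > 40000 nM, a limit of the assay and not a number. No step can be read among compound 1, compound 2 and compound 3, as all three stand at one limit: the limit of > 40000 nM in this assay, at which 3 of the 3 values shown sit. The compounds shown leave open whether any group at this place on the aromatic ring gives a readable value.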